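The source may hold more compounds than are shown below. What is called first, only, known or untested is meant among the compounds shown, and "the series" means these compounds.

Compound 1 `Cc1ccn2nc(C)c(C(=O)NCc3ccc(N4CCCCC4)cc3)c2c1`: in an ADME assay on Vero cells (Chlorocebus sabaeus) for cytotoxicity, read by CCK-8 assay, with a stated time of 72 h (a higher number here means a weaker inhibitor, a lower number a stronger inhibitor), compound 1 gives > 100000 nM, which is a limit of the assay and not a number.
Compound 2 `Cc1ccn2nc(C)c(C(=O)NCc3ccc(N4CCC(C(F)(F)F)CC4)cc3)c2c1`: in this assay compound 2 gives > 100000 nM, again a limit of the assay.
Compound 3 `Cc1nn2c(C)cccc2c1C(=O)NCc1ccc(N2CCC(c3ccc(OC(F)(F)F)cc3)CC2)cc1`: in this assay compound 3 gives "not determined" (no result reported).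

Compound 3 thus has no number of its own in this assay; the two values shown for the series both sit at a limit, as noted in the limit of > 100000 nM in this assay, at which 2 of the 3 values shown sit. Going by the values given here, the only measured step, a step that the two limits leave unreadable from compound 1 to compound 2, is unreadable for the same reason, so no size of effect can be taken from it.

Compound 4 `CCc1nn2ccc(Cl)cc2c1C(=O)NCc1ccc(N2CCC(c3ccc(OC(F)(F)F)cc3)CC2)cc1` differs from compound 3 by a group of 12 heavy atoms (9 carbon, 2 nitrogen, 1 chlorine; one five-membered aromatic ring with 2 hetero atoms, one six-membered aromatic ring with 1 hetero atom) in place of a group of 11 heavy atoms (9 carbon, 2 nitrogen; one five-membered aromatic ring with 2 hetero atoms, one six-membered aromatic ring with 1 hetero atom), on a carbonyl carbon. Among the compounds with values here, no measured step bears on this change, and the shared part of the series gives only limits, so no direction beyond the scatter is expected in this assay. The expectation for compound 4 is that the assay again reports a limit, with an estimate of 100000 nM and a range from 30000 nM to 300000 nM.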

Compound 4, half-maximal inhibitory concentration: > 100000 nM
Compound 4: a limit, no number; the forecaster's own chance of this, stated with the estimate: 80%; the middle value lies on the limit itself.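

In this assay compound 4 gives > 100000 nM, a limit and not a number. Compound 3 has no number to set against it, so no step can be read between compound 3 and compound 4. The compounds shown leave open what half-maximal concentration any of them would reach in this assay: the limit of > 100000 nM in this assay, at which 3 of the 4 values shown sit.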